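The source may hold more compounds than are shown below. What is called first, only, known or untested is meant among the compounds shown, and "the series" means these compounds.

Measured so far in a functional assay on HeLa cells (Homo sapiens) for antiproliferative activity, read by CCK-8 assay, with a stated time of 72 h; a lower number here means a stronger inhibitor, a higher number a weaker inhibitor:
compound 1 `O=C(Nc1cccc(-c2oc3cc(-c4ccc(F)cc4)ccc3c(=O)c2O)c1)c1ccccc1F` — 5630 nM
compound 2 `O=C(Nc1cccc(-c2oc3cc(-c4ccc(F)cc4)ccc3c(=O)c2O)c1)c1ccc(F)cc1F` — 10700 nM
compound 3 `COc1ccccc1C(=O)Nc1cccc(-c2oc3cc(-c4ccc(F)cc4)ccc3c(=O)c2O)c1` — 14100 nM

Compound 1 holds the lowest of the three numbers in this assay. Compound 2 sits within the scatter of it, a 1.9-fold higher number from compound 1 to compound 2 (0.28 log units; within the scatter), whereas compound 3 lies beyond it, a 2.5-fold higher number from compound 1 to compound 3 (0.40 log units; beyond the scatter); between compound 2 and compound 3 the step is a 1.3-fold higher number from compound 2 to compound 3 (0.12 log units; within the scatter).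

Compound 4 `Cc1ccccc1C(=O)Nc1cccc(-c2oc3cc(-c4ccc(F)cc4)ccc3c(=O)c2O)c1` is the next step out from compound 1: methyl in place of fluoro on an aromatic carbon. The measured step that bears most directly on this position is a 2.5-fold higher number from compound 1 to compound 3 (0.40 log units; beyond the scatter), a modest loss when the fluoro gives way to methoxy on the same aromatic carbon; the other change at this ring, a 1.9-fold higher number from compound 1 to compound 2 (0.28 log units; within the scatter), stayed within the scatter. For the measured compounds named here, nothing measured so far separates a methyl from either of those groups at this place, so the expectation is for a small loss at most, of the order seen in a 2.5-fold higher number from compound 1 to compound 3 (0.40 log units; beyond the scatter) or less. Expected, on this reading, is a 1.3-fold higher number from compound 1 to compound 4 (0.12 log units; within the scatter). Compound 4 is estimated at 7500 nM, with a range from 3500 nM to 16000 nM.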

Compound 4, half-maximal inhibitory concentration: 11900 nM
Beside the measured number, compound 4's estimate is 1.6-fold (0.20 log units) below it, within the range that was stated.
By their numbers in this assay, from the lowest: compounds 1, 2, 4 and 3 (each within the scatter of the next, the first and the last beyond it).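

With methyl on this aromatic carbon, a second replacement of the fluoro in this assay falls beyond the scatter (a 2.1-fold higher number from compound 1 to compound 4 (0.33 log units; beyond the scatter)), so the modest loss seen with methoxy is no longer a single case. Methyl and methoxy are not separated at this place (a 1.2-fold lower number from compound 3 to compound 4 (0.07 log units; within the scatter)), and 2-methylphenyl on the carbonyl carbon is likewise not separated from 2,4-difluorophenyl (a 1.1-fold higher number from compound 2 to compound 4 (0.05 log units; within the scatter)). No accompanying measurement offers an explanation for these steps.

The three compounds shown leave open whether the advantage of the 2-fluorophenyl group belongs to fluoro alone, which a chloro group or plain hydrogen on this carbon would test. As far as these compounds go, how an amine, a carboxylic acid or a longer chain such as ethyl would read here also remains open.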